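The source may report more compounds than this note shows. Statements on the series, on what has been measured and on what is new or still open speak of the compounds shown alone.

Working notes on the series. Among the measured compounds shown here, in an ADME assay on microsomes from liver (Homo sapiens) for metabolic stability (on this read-out higher numbers stand for fast clearance and lower numbers for slow clearance), compound 1 `Cc1oc(-c2ccc(Cl)cc2)nc1C(=O)N[C@H]1CN(S(=O)(=O)c2ccccc2)C[C@@H]1C(=O)N[C@H]1CCCNC1` gives 4.9 mL.min-1.g-1, the only actual number so far. Compound 2 `O=C(N[C@H]1CN(S(=O)(=O)c2ccccc2)C[C@@H]1C(=O)N[C@H]1CCCNC1)c1cc(-c2ccc(Cl)cc2Cl)on1` is reported only as a limit, < 3 mL.min-1.g-1. For the measured compounds named here, compound 2 differs from compound 1 in more than one place, so the pair yields no clean single-change step, and no measured step of that kind exists in this set.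

The next compound to be read is compound 3 `Cc1oc(-c2ccccc2Cl)nc1C(=O)N[C@H]1CN(S(=O)(=O)c2ccccc2)C[C@@H]1C(=O)N[C@H]1CCCNC1`. It keeps the rest of compound 1 and swaps the position of the chlorine on the phenyl group: 2-chlorophenyl in place of 4-chlorophenyl on an aromatic carbon. In words, 2-chlorophenyl stands in place of 4-chlorophenyl on an aromatic carbon, with the same atoms joined differently.

Going by the values given here, with no measured step to guide the size or direction of the change, no shift beyond the scatter is expected in this assay. The expectation therefore starts from compound 1 at 4.9 mL.min-1.g-1. The expected change is small, a 1.1-fold lower number from compound 1 to compound 3 (0.04 log units; within the scatter), and lies within the usual scatter. For compound 3 the estimated clearance is 4.5 mL.min-1.g-1, with an expected range from 3 mL.min-1.g-1 to 9 mL.min-1.g-1.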

Compound 3, intrinsic clearance in microsomes in the Homo sapiens assay: < 3 mL.min-1.g-1
Compound 3 ended at the assay's limit; the forecaster's own chance of this, stated with the estimate: 25%; middle value at least 1.5-fold (0.17 log units) from the limit.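

Among the compounds shown here, in the Homo sapiens assay compound 3 gives < 3 mL.min-1.g-1, a limit of the assay, and the move of the chlorine gives the first single-change step, an at least 1.6-fold lower number from compound 1 to compound 3 (0.21 log units; that floor lies within the scatter), so 2-chlorophenyl in place of 4-chlorophenyl on this aromatic carbon brings no rise in clearance, although the true size of the step stays unknown. In a physicochemical assay for solubility, at pH 7.4 (a lower number here means a less soluble compound, a higher number a more soluble compound), compound 1 gives 15000 nM and compound 3 gives 10000 nM; the same change reads a 1.5-fold lower number from compound 1 to compound 3 (0.18 log units; within the scatter), so on this read-out too the position of the chlorine on the phenyl group shows no shift beyond the scatter. The value of compound 3 in the Homo sapiens assay is a limit, so the step can be read only as a floor, and compounds sitting at that limit cannot be ranked against one another: the limit of < 3 mL.min-1.g-1 in the Homo sapiens assay, at which 2 of the 3 values shown sit.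

The compounds shown leave open how the read-outs of the Homo sapiens assay and the physicochemical assay respond when an amine, a methoxy group or a carboxylic acid takes the place of the chlorine on the phenyl group. They also leave open how far past its limit compound 3 lies, and so whether the step from the chlorine move is small or large.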